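Chlorophenyl for pyridyl on the shared core

The source may report more compounds than this note shows. Statements on the series, on what has been measured and on what is new or still open speak of the compounds shown alone.

Going by the values given here, compound 1 `Clc1ccc(-c2cc(-c3cccnc3)nc(-c3ccsc3)c2)o1` gives 0% in an assay on isolated protein for inhibition of DNA topoisomerase 1 (Homo sapiens), tested at 100 uM (on this read-out lower numbers stand for a weaker effect and higher numbers for a stronger effect at the one concentration tested), the lowest of the three numbers measured so far. Compound 3 `Clc1ccc(-c2cc(-c3cccnc3)nc(-c3cccs3)c2)o1` gives 25.8%, and compound 2 `Clc1ccc(-c2cc(-c3cccs3)nc(-c3ccccc3Cl)c2)o1` gives 41.3%. Compound 4 `Clc1cccc(-c2cc(-c3ccc(Cl)o3)cc(-c3ccsc3)n2)c1` differs from compound 1 by 3-chlorophenyl in place of pyridin-3-yl on an aromatic carbon. Of the measured steps, the one that bears on this change is a number 15.5 percentage points lower from compound 2 to compound 3 (beyond the scatter), which runs in the opposite direction to the change now made; the step of a number 25.8 percentage points higher from compound 1 to compound 3 (beyond the scatter) concerns another part of the shared core and offers no guidance here. A rise of comparable size beyond the scatter is therefore expected, a number 15 percentage points higher from compound 1 to compound 4 (beyond the scatter). Compound 4 is expected to give 15%, with a range from 0% to 35%.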

Compound 4, a percentage reported as inhibition, at one concentration (the size of the read-out at that concentration, not a potency): 0%
The estimate for compound 4 lay 15 percentage points above the measured number; measured number inside the range.
By their numbers in this assay, from the lowest: compounds 1 and 4 (each within the scatter of the next); then compound 3; then compound 2.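

With thiophen-3-yl on the shared core, 3-chlorophenyl in place of pyridin-3-yl gives no change at the digits printed from compound 1 to compound 4 (within the scatter) in this assay, so this change brings no gain at this position. Going by these compounds alone, the difference seen with thiophen-2-yl on the core, a number 15.5 percentage points lower from compound 2 to compound 3 (beyond the scatter), has no counterpart here, although that pair carries 2-chlorophenyl and not 3-chlorophenyl. No measurement on hand explains this result.

Going by these compounds, whether 3-chlorophenyl gives a higher number alongside thiophen-2-yl remains open. So does whether an aminomethyl group or a carboxylic acid on this phenyl ring would move the number above that of compound 1.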